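The source may report more compounds than this note shows. Statements on the series, on what has been measured and on what is new or still open speak of the compounds shown alone.

Compounds measured in a functional assay on RPMI-8226 cells (Homo sapiens) for inhibition; a higher number here means a weaker inhibitor, a lower number a stronger inhibitor:
compound 1 `CC(C)(C)NC(=O)N1CC1C#N` gives 216000 nM;
compound 2 `CCOC(=O)c1ccc(NC(=O)N2CC2C#N)cc1` gives 3000 nM;
compound 3 `N#CC1CN1C(=O)Nc1cccc2ccccc12` gives 8900 nM.

Compound 2 holds the lowest number of the three; compound 3 stands beyond the scatter from it, and compound 1 stands far further away. Compound 4 `N#CC1CN1C(=O)Nc1ccc(C(F)(F)F)cc1` differs from compound 2 in one place: trifluoromethyl in place of ethoxycarbonyl on an aromatic carbon, with trifluoromethyl in place of ethoxycarbonyl on an aromatic carbon. Within the data shown here, no measured pair shows this exact change, so the size of the step is open. The two aromatic compounds, compound 2 and compound 3, both lie well under compound 1, so compound 4 is expected to stay in their range. The step from compound 2 to compound 4 is estimated as a 2.0-fold higher number from compound 2 to compound 4 (0.30 log units; within the scatter), a modest rise. Compound 4 is therefore expected at about 6000 nM, within 1500 nM to 25000 nM.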

Compound 4, half-maximal inhibitory concentration: 7800 nM
For compound 4 the middle estimate is 1.3-fold (0.11 log units) below the measured one; measured number inside the range.
By their numbers in this assay, from the lowest: compound 2; then compounds 4 and 3 (each within the scatter of the next); then compound 1.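

Among these compounds, on the aromatic carbon of compound 2, in this assay, replacing ethoxycarbonyl with trifluoromethyl gives a 2.6-fold higher number from compound 2 to compound 4 (0.41 log units; beyond the scatter), the first one-place step at this position. The change is modest but beyond the scatter, so this position responds to the group it carries, yet it still accepts a group with 0 hydrogen-bond acceptors in place of one with 2. Nothing at hand accounts for the size of this step. From the compounds shown here alone, whether a carboxylic acid, an amine or a longer ester chain at this carbon would give a lower number stays open, as does which part of ethoxycarbonyl matters, its carbonyl or its ethyl chain.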